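The source may hold more compounds than are shown below. What is called first, only, known or untested is meant among the compounds shown, and "the series" means these compounds.

Compound 1 (`COC(=O)C(=O)N[C@@H](CO)C(=O)O`), compound 2 (`CC(C)C(=O)N[C@@H](CO)C(=O)O`) and compound 3 (`COC(=O)N[C@@H](CO)C(=O)O`) share one core. Among the measured compounds shown here, in an ADME assay on microsomes from liver (Homo sapiens) for metabolic stability, with a stated time of 30 min (a lower number here means that less of the compound is left, a higher number that more of the compound is left), compound 1 has "not determined" (no result reported) as its entry, and compound 2 gives 84% as the only number available. Compound 3 differs from compound 2 by one change (methoxy in place of isopropyl on a carbonyl carbon): methoxy in place of isopropyl on a carbonyl carbon. For the measured compounds named here, no measured step shows how such a change acts, so with compound 2 at 84% as the sole anchor, no shift beyond the scatter is expected in this assay. The expected change is a number 4 percentage points lower from compound 2 to compound 3 (within the scatter) and stays within the scatter. For compound 3 the estimated value is 80% (range 62% to 95%).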

Compound 3, percent of the compound remaining: 43%
Compound 3: the middle estimate sits 37 percentage points above what was measured; the measured number lies below the stated range.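

In this assay, the group on a carbonyl carbon whose other neighbours are the amide-type nitrogen proves to matter: methoxy in place of isopropyl gives a number 41 percentage points lower from compound 2 to compound 3 (beyond the scatter), a step beyond the scatter. Among the compounds shown here, this is the first measured step at this position, and it shows that the position is sensitive to this change. Nothing shown here accounts for the size of the step. Still open, from the compounds shown here alone, is how an amine, an ethoxy group or a longer chain on that carbonyl carbon would behave, and whether any of them would stay closer to compound 2 or to compound 3.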